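This account rests on a few compounds, and the source may have more. Where it says the series, first, only, none or still open, it means among the compounds named here.

Measured in a functional assay on BaF3 cells (Mus musculus) for antiproliferative activity, with a stated time of 48 h; a lower number here means a stronger inhibitor, a higher number a weaker inhibitor:
- Compound 1 `COc1cc(-c2cn([C@H]3C[C@@H](N4CCN(C(C)=O)CC4)C3)c3ncnc(N)c23)ccc1Cl`: > 10000 nM (a limit)
- Compound 2 `Nc1ncnc2c1c(-c1cccc(O)c1)cn2[C@H]1C[C@@H](CO)C1`: 1300 nM

Going by the values given here, compound 2 holds the only actual number so far, at 1300 nM in this assay. The other result is not a number: compound 1 is reported only as a limit, > 10000 nM.

Compound 3 `CC(=O)N1CCN([C@H]2C[C@@H](n3cc(-c4cccc(O)c4)c4c(N)ncnc43)C2)CC1` has yet to be measured. It has 4-acetylpiperazin-1-yl in place of hydroxymethyl on a saturated ring carbon of a four-membered non-aromatic ring of carbon only, compared with compound 2: 4-acetylpiperazin-1-yl in place of hydroxymethyl on a saturated ring carbon. Among the compounds with values here, no measured step isolates this change. Compound 1 carries the same incoming group but also differs elsewhere, so its limit of > 10000 nM is only a weak guide, and it points to a moderate weakening in this assay. The expected change is a 1.9-fold higher number from compound 2 to compound 3 (0.28 log units; within the scatter). For compound 3 the estimate is 2500 nM, with an expected range of 500 nM to 10000 nM.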

Compound 3, half-maximal inhibitory concentration: > 10000 nM
Compound 3 ended at the assay's limit (the forecaster's own chance of this, stated with the estimate: 20%); middle value at least 4.0-fold (0.60 log units) away from the limit.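

Replacing hydroxymethyl with 4-acetylpiperazin-1-yl on this saturated ring carbon gives an at least 7.6-fold higher number from compound 2 to compound 3 (0.88 log units; beyond the scatter) in this assay, so this change on its own costs activity, which compound 1 could not show with its different 4-chloro-3-methoxyphenyl group. The full size of this step cannot be read, as compound 3 is reported only as a limit: the limit of > 10000 nM in this assay, at which 2 of the 3 values shown sit. The step from compound 1 to compound 3 cannot be read either, since both values are limits.

The compounds shown leave open whether the loss follows from the acetyl group, the six-membered ring or the larger group as a whole. As far as these compounds go, how aminomethyl or piperazin-1-yl without its acetyl group would behave on this ring carbon also remains open.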